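Putting an Aromatic Acyl Group on a Hydroxy

The source may hold more compounds than are shown below. What is called first, only, known or untested is meant among the compounds shown, and "the series" means these compounds.

In an ADME assay on cells (Hepatocyte, Homo sapiens) for metabolic stability, with a stated time of 30 min (a higher number here means that more of the compound is left, a lower number that less of the compound is left), compound 3 (`O=c1cc(N2CCN(CC3CCC(O)CC3)CC2)sc2c([N+](=O)[O-])cc(C(F)(F)F)cc12`) gives 72.7%. That is the second highest of three numbers. Compound 1 (`O=C(NC1CCC(CN2CCN(c3cc(=O)c4cc(C(F)(F)F)cc([N+](=O)[O-])c4s3)CC2)CC1)c1ccccc1`) ranks first with 92.9%. Compound 2 (`CC(=O)OC1CCC(CN2CCN(c3cc(=O)c4cc(C(F)(F)F)cc([N+](=O)[O-])c4s3)CC2)CC1`) ranks last with 0%.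

Compound 4 (`COc1ccc(C(=O)OC2CCC(CN3CCN(c4cc(=O)c5cc(C(F)(F)F)cc([N+](=O)[O-])c5s4)CC3)CC2)cc1`) differs from compound 3 as follows: (4-methoxyphenyl)carbonyl in place of hydrogen on an oxygen on a saturated carbon. In words, (4-methoxyphenyl)carbonyl stands in place of hydrogen on an oxygen on a saturated carbon, so hydroxy becomes ((4-methoxyphenyl)carbonyl)oxy.

The closest evidence is compound 2, which carries acetyl on that same oxygen. The measured step is a number 72.7 percentage points higher from compound 2 to compound 3 (beyond the scatter), so there the group on the oxygen went with a large loss in this assay. Compound 1 offers a partial counterweight, since it holds an aromatic ring through benzamido, not through oxygen. Its steps are a number 92.9 percentage points lower from compound 1 to compound 2 (beyond the scatter) and a number 20.2 percentage points lower from compound 1 to compound 3 (beyond the scatter). Within the data shown here, no measured compound has an aromatic group on that oxygen, so the size of the step remains uncertain, though its direction seems clearer. A large fall is expected, namely a number 57.7 percentage points lower from compound 3 to compound 4 (beyond the scatter). For compound 4 the estimated value is 15%, with an expected range from 0% to 50%.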

Compound 4, percent of the compound remaining: 12.2%
Beside the measured number, compound 4's estimate is 2.8 percentage points above it, and the stated range covers the measured number.
By their numbers in this assay, from the lowest: compound 2; then compound 4; then compound 3; then compound 1.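

Adding the aromatic acyl group costs nearly as much as acetyl did: in this assay, there is a number 60.5 percentage points lower from compound 3 to compound 4 (beyond the scatter) as the hydroxy becomes ((4-methoxyphenyl)carbonyl)oxy, so among the compounds shown, the large loss on acylating this oxygen is not limited to acetyl. Changing the group on the carbonyl carbon from methyl to 4-methoxyphenyl recovers little, with a number 12.2 percentage points higher from compound 2 to compound 4 (beyond the scatter) and most of the loss of compound 3's level still in place. An aromatic ring alone therefore does not secure a high number at this position, since there is a number 80.7 percentage points lower from compound 1 to compound 4 (beyond the scatter) even though both compounds carry such a ring, although they differ in the ring's methoxy group as well as in how the ring is attached.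

The compounds shown offer no measurement that explains why either acylated compound falls so far in this assay. Going by these compounds, it remains open how a methyl ether on this oxygen would behave, and whether an acetamido group on the same saturated ring carbon would keep a high number without any aromatic ring.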